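One Aryl Swap on the Aromatic Nitrogen

The compounds below may be only part of what the source reports. "The series", "measured", "known", "first", "only" and "open" are said of these compounds alone.

Compound 1 `O=C(Nc1ccc(Oc2ccnc3[nH]ccc23)cc1)c1cn(-c2ccc(Cl)cc2)c2ccccc2c1=O`: 650 nM
Compound 2 `Cn1ccc2c(Oc3ccc(NC(=O)c4cn(-c5ccc(Br)cc5F)c5ccccc5c4=O)cc3F)ccnc21`: 1520 nM

In a functional assay on A549 cells (Homo sapiens) for inhibition, read by MTT assay, with a stated time of 72 h (a higher number here means a weaker inhibitor, a lower number a stronger inhibitor), compound 1 gives 650 nM and compound 2 gives 1520 nM. Compound 2 stands with the higher of the two numbers, and its gap to compound 1 lies beyond the usual scatter. Compound 3 `COc1ccc(-n2cc(C(=O)Nc3ccc(Oc4ccnc5c4ccn5C)c(F)c3)c(=O)c3ccccc32)cc1` differs from compound 2 by 4-methoxyphenyl in place of 4-bromo-2-fluorophenyl on an aromatic nitrogen. Going by the values given here, no measured pair shows this change, so no step can be read from the data for it. In this assay the expected step is a 1.2-fold higher number from compound 2 to compound 3 (0.07 log units; within the scatter), small and uncertain in direction. Compound 3 is therefore estimated at 1800 nM, with a range from 600 nM to 6000 nM.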

Compound 3, half-maximal inhibitory concentration: 3210 nM
For compound 3 the middle estimate is 1.8-fold (0.25 log units) below the measured one; the measured number falls inside the stated range.
By their numbers in this assay, from the lowest: compound 1; then compound 2; then compound 3.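

In this assay, 4-methoxyphenyl in place of 4-bromo-2-fluorophenyl on the aromatic nitrogen gives a 2.1-fold higher number from compound 2 to compound 3 (0.32 log units; beyond the scatter), so the aryl group at this position does affect the read-out, which the earlier pair, differing in more than one place, could not show. Nothing in the data explains this step.

As far as these compounds go, the swap removes bromine and fluorine and adds methoxy all at once, so the share of each remains open. From the compounds shown here alone, whether an unsubstituted phenyl or a 4-aminophenyl group here would fall closer to compound 2 or compound 3 also remains open.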